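The source may report more compounds than this note shows. Statements on the series, on what has been measured and on what is new or still open speak of the compounds shown alone.

Measured so far:
compound 1, `CCCCOC(=O)Nc1ccc2ccn(Cc3ccc(C(=O)O)cc3OC)c2c1`: 155 nM
compound 2, `COc1cc(C(=O)NS(=O)(=O)c2ccccc2C)ccc1Cn1ccc2ccc(NC(=O)CC3CCCC3)cc21`: 0.106 nM
compound 3, `COc1cc(C(=O)NS(=O)(=O)c2ccccc2C)ccc1Cn1cc(CC(C)C(=O)N(C)C)c2ccc(C(=O)NCC3CCCC3)cc21`: 0.65 nM

In a functional assay on trachea for agonist activity at cysteinyl leukotriene receptor (Homo sapiens) (a lower number here means a stronger inhibitor, a higher number a weaker inhibitor), compound 3 holds the second highest of the three numbers. Its nearest neighbour is compound 2, whose lower number lies beyond the scatter of this assay; compound 1 sits far away at a much higher number, also beyond the scatter. No pair among these three differs in only one place, so no single-change step is available for calibration, and the gap between compound 2 and compound 3 can only be read as what the two values show.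

The next compound in the series is compound 4, `CNC(=O)CCc1cn(Cc2ccc(C(=O)NS(=O)(=O)c3ccccc3C)cc2OC)c2cc(C(=O)NCC3CCCC3)ccc12`. It differs from compound 3 in one place: (methylcarbamoyl)methyl in place of 1-(dimethylcarbamoyl)ethyl on a saturated chain carbon bound to an aromatic carbon. Both the leaving and the entering group are short amide-bearing chains on the same chain carbon, and the rest of the molecule is unchanged. Without a measured step of this kind in the series, the expectation rests only on the small size of the change; a step from compound 3 to compound 4 of a 1.5-fold higher number from compound 3 to compound 4 (0.19 log units; within the scatter) is expected, that is, little movement and possibly none beyond the scatter. Compound 4 is thus estimated to give 1 nM in this assay, with a range from 0.3 nM to 3.5 nM.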

Compound 4, antagonist equilibrium constant: 0.399 nM
Compound 4: the middle estimate sits 2.5-fold (0.40 log units) above what was measured, and the stated range covers the measured number.
By their numbers in this assay, from the lowest: compound 2; then compounds 4 and 3 (each within the scatter of the next); then compound 1.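

In this assay, among the compounds shown here, the exchange of 1-(dimethylcarbamoyl)ethyl for (methylcarbamoyl)methyl on a saturated chain carbon bound to an aromatic carbon gives a 1.6-fold lower number from compound 3 to compound 4 (0.21 log units; within the scatter) and is the first single-place step, so this position now has a calibration point that the earlier compounds could not supply. The entering group has 5 heavy atoms against 7 and 1 hydrogen-bond donor against 0, yet the two compounds cannot be told apart in this read-out, so at this position neither difference in this exchange registers beyond the scatter. No measurement on hand bears on why the number stays within the scatter.

The step changes the chain and the amide substitution together, so it cannot separate them; (dimethylcarbamoyl)methyl and 1-(methylcarbamoyl)ethyl would pull the two apart. On these data alone, whether the amide itself matters at this position also stays open, and a carboxylic acid, an amine or a longer chain carrying the same amide would address that.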